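The source may hold more compounds than are shown below. What is called first, only, known or untested is meant among the compounds shown, and "the series" means these compounds.

Measured compounds:
compound 1 `CC[C@H](C)C(N)c1cc(C(F)(F)F)ccc1N1CCN(C(=O)CCc2ccc(Cl)cc2Cl)CC1` — 75 nM in an assay on HEK293 cells for displacement of a labelled ligand from Melanocortin receptor 4 (Homo sapiens); on this read-out higher numbers stand for weaker inhibition and lower numbers for stronger inhibition
compound 2 `CCN[C@H](c1cc(C(F)(F)F)ccc1N1CCN(C(=O)CCc2ccc(Cl)cc2Cl)CC1)C(C)CC` — 92 nM in this assay

Compound 2 gives the higher of the two numbers, but a 1.2-fold higher number from compound 1 to compound 2 (0.09 log units; within the scatter) leaves it within the scatter of compound 1. Compound 3 `CCC(C)[C@H](NC[C@H](C)N)c1cc(C(F)(F)F)ccc1N1CCN(C(=O)CCc2ccc(Cl)cc2Cl)CC1` carries 1-aminoethyl in place of methyl on a saturated chain carbon bound to an amine nitrogen. Going by the values given here, the only step bearing on it is the earlier growth of the amine substituent, a 1.2-fold higher number from compound 1 to compound 2 (0.09 log units; within the scatter), which left the number unchanged within the scatter; a step of a 1.1-fold higher number from compound 2 to compound 3 (0.04 log units; within the scatter) is therefore expected, i.e. none beyond the scatter. For compound 3 a value of 100 nM in this assay is estimated, expected between 40 nM and 250 nM.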

Compound 3, inhibition constant: 89 nM
For compound 3 the middle estimate is 1.1-fold (0.05 log units) above the measured one, within the range that was stated.
By their numbers in this assay, from the lowest: compounds 1, 3 and 2 (each within the scatter of the next).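

In this assay, 1-aminoethyl in place of methyl on a saturated chain carbon bound to an amine nitrogen gives a 1.0-fold lower number from compound 2 to compound 3 (0.01 log units; within the scatter), and the full change from 1-amino-2-methylbutyl gives a 1.2-fold higher number from compound 1 to compound 3 (0.07 log units; within the scatter). This position therefore accepts a group bearing a further amine, with one more hydrogen-bond donor and acceptor and a defined stereocentre, with no shift beyond the scatter. No data on hand account for this result.

Still open, as far as these compounds go, is whether a carboxylic acid or a longer chain here would shift the number beyond the scatter. From the compounds shown here alone, the opposite configuration of the 1-aminoethyl stereocentre also remains open.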